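Replacing an amide with a ketone on a shared core

A few compounds are considered here, and "the series" means these few. Any claim that something is new, unique, unknown or untested is made for them only; others in the source may bear on it.

Compound 2 `N#C/C(=C\N1CCN(C(=O)c2ccco2)C1=S)C(N)=O` gives 24400 nM in a functional assay on SK-MEL-2 cells (Homo sapiens) for inhibition, read by sulforhodamine B assay, with a stated time of 48 h (on this read-out higher numbers stand for weaker inhibition of growth and lower numbers for stronger inhibition of growth), the higher of the two numbers recorded, while compound 1 `N#C/C(=C\N1CCN(C(=O)c2ccco2)C1=S)C(=O)Nc1ccc(Cl)cc1` gives 16700 nM. Among the measured compounds shown here, the only measured step, a 1.5-fold higher number from compound 1 to compound 2 (0.16 log units; within the scatter), lies within the scatter. Compound 3 `N#C/C(=C\N1CCN(C(=O)c2ccco2)C1=S)C(=O)c1ccccc1` carries a further change at this end of the molecule: phenyl in place of amino on a carbonyl carbon. For the measured compounds named here, since the one step that touches this part of the structure stayed within the scatter, no step beyond the scatter is expected here either. Compound 3 is therefore expected to give about 18000 nM, between 6000 nM and 55000 nM, in this assay, a shift of a 1.4-fold lower number from compound 2 to compound 3 (0.13 log units; within the scatter).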

Compound 3, concentration for 50% growth inhibition: 3700 nM
Compound 3: middle estimate off by 4.9-fold (0.69 log units), on the high side; the measured number lies below the stated range.
By their numbers in this assay, from the lowest: compound 3; then compounds 1 and 2 (each within the scatter of the next).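

In this assay, this end of the molecule proves able to change the result: phenyl on the carbonyl carbon gives a 6.6-fold lower number from compound 2 to compound 3 (0.82 log units; beyond the scatter), and against the larger anilide it gives a 4.5-fold lower number from compound 1 to compound 3 (0.65 log units; beyond the scatter). The earlier step between the two amides stayed within the scatter, so only this swap of an amide for a ketone has shown a change that can be read. Nothing measured here bears on why the number fell. From the compounds shown here alone, whether a ring is needed on this carbonyl carbon stays open, since a methyl or a cyclohexyl group there could give a different number.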